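Removing the piperidine from an alkyne-linked TLR8 agonist

This account rests on a few compounds, and the source may have more. Where it says the series, first, only, none or still open, it means among the compounds named here.

The measured compounds:
compound 1, `CCCCNc1nc(N)nc(C)c1CCCN1C(=O)c2ccccc2C1=O`, 453 nM
compound 2, `CCCCNc1nc(N)nc(C)c1C#CCN1CCCCC1`, 3790 nM
compound 3, `CCCCNc1nc(N)nc(C)c1CCCN1CCCCCC1`, 178 nM

In an assay on HEK293 cells for agonist activity at Toll-like receptor 8 (Homo sapiens), read by spectrophotometry (on this read-out lower numbers stand for an effect already at smaller amounts and higher numbers for an effect only at larger amounts of compound), compound 2 gives the highest of the three numbers; compound 1 and compound 3 both lie well beyond the scatter from it, and the gap from compound 2 to compound 3 is the widest. Compound 4, `CCCC#Cc1c(C)nc(N)nc1NCCCC`, is compound 2 with ethyl in place of piperidin-1-yl on a saturated chain carbon bound to a triple-bonded carbon. Compound 1 shows that a compound without a basic ring nitrogen can still give a modest number, so a large loss is not forced. Still, the chain of compound 4 is stripped to a bare alkyne, and the step from compound 2 to compound 4 is expected to be a 1.8-fold higher number from compound 2 to compound 4 (0.27 log units; within the scatter), a weakening of moderate size. Compound 4 is estimated at 7000 nM, within 1800 nM to 28000 nM.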

Compound 4, half-maximal effective concentration: 5000 nM
Compound 4: the middle estimate sits 1.4-fold (0.15 log units) above what was measured; the measured number falls inside the stated range.
By their numbers in this assay, from the lowest: compound 3; then compound 1; then compounds 2 and 4 (each within the scatter of the next).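

Exchanging piperidin-1-yl for ethyl on a saturated chain carbon bound to a triple-bonded carbon leaves the reading in this assay within the scatter, with a 1.3-fold higher number from compound 2 to compound 4 (0.12 log units; within the scatter). On this alkyne chain, then, the six-membered ring and its nitrogen can be lost without a change that can be told from scatter, and the ethyl compound stays level with the piperidine compound. No available evidence offers an explanation for this result.

Still open, as far as these compounds go, is whether a primary amine, a hydroxyl group or a longer chain at this carbon would shift the number. Also open, from the compounds shown here alone, is whether the same exchange would hold on a saturated linker.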